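This account rests on a few compounds, and the source may have more. Where it says the series, first, only, none or still open, it means among the compounds named here.

Two measured compounds share one core: compound 1 `CC(=O)N1CCN(CCCCOc2ccccc2/C=C/c2ccccc2)CC1` and compound 2 `NC(=O)C1CCCN(CCCCOc2ccccc2/C=C/c2ccccc2)C1`. In a functional assay on the whole organism with Mus musculus as the target, in the maximal electroshock model, at a dose of 50 mg/kg by the oral route (a lower number here means less inhibition, a higher number more inhibition at the dose given (going by the name of the read-out)), compound 1 gives 0%, and in this assay compound 2 gives 0%. The single measured step, no change at the digits printed from compound 1 to compound 2 (within the scatter), is thus flat, and compound 2 stands level with compound 1 on the numbers shown.

The unmeasured compound 3 `O=C(O)C1CCCN(CCCCOc2ccccc2/C=C/c2ccccc2)C1` differs from compound 2 in one place: hydroxy in place of amino on a carbonyl carbon. Within the data shown here, no measured step involves this exchange of hydroxy for amino, so the only guide is the flat step already seen, which changed the ring substituent without moving the read-out. With both measured compounds at the floor of the scale, the expected step of a number 5 percentage points higher from compound 2 to compound 3 (within the scatter) is none beyond the scatter. Compound 3 is therefore estimated at 5%, with a range from 0% to 25% in this assay.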

Compound 3, a percentage reported as inhibition, in the whole organism at one dose (the size of the read-out at that dose, not a potency): 12.5%
Beside the measured number, compound 3's estimate is 7.5 percentage points below it; low and high end bracket the measured number.
By their numbers in this assay, from the lowest: compounds 1 and 2 (each within the scatter of the next); then compound 3.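

In this assay, among these compounds, replacing amino with hydroxy on a carbonyl carbon, which turns carbamoyl into carboxy, produces the only measured single-group exchange here to move the read-out beyond the scatter (a number 12.5 percentage points higher from compound 2 to compound 3 (beyond the scatter)). The larger exchange of 4-acetylpiperazin-1-yl for 3-carboxypiperidin-1-yl shows a modest rise of the same printed size (a number 12.5 percentage points higher from compound 1 to compound 3 (beyond the scatter)), so this part of the molecule can shift the result at this one dose, though only slightly. No evidence is available to explain the rise.

The compounds shown leave open whether a methoxy group on the same carbonyl carbon, giving a methyl ester, would keep this rise. They also leave open how a longer chain would change the read-out when paired with 3-carboxypiperidin-1-yl.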